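Fluoro for methyl on the sulfonamide aryl of compound 2

This account rests on a few compounds, and the source may have more. Where it says the series, first, only, none or still open, it means among the compounds named here.

Within the data shown here, compound 2 `CCN1C(N(C)C)=Nc2ccccc2C1CC(=O)NCc1ccc(NS(=O)(=O)c2ccc(C)cc2)cc1` gives 1120 nM in an assay on HEK293 cells for inhibition of Voltage-dependent T-type calcium channel subunit alpha-1G (Homo sapiens) (a higher number here means a weaker inhibitor, a lower number a stronger inhibitor), the higher of the two numbers measured so far. Its nearest neighbour, compound 1 `CN(C)C1=Nc2ccccc2C(CC(=O)NCc2ccc(NS(=O)(=O)c3ccc(F)cc3)cc2)N1c1ccccc1`, gives 430 nM in this assay, a gap beyond the usual scatter; the two structures differ in more than one place, so no single step can be read from them. Compound 3 `CCN1C(N(C)C)=Nc2ccccc2C1CC(=O)NCc1ccc(NS(=O)(=O)c2ccc(F)cc2)cc1` is the next compound and differs from compound 2 in one place: fluoro in place of methyl on an aromatic carbon. Among the measured compounds shown here, compound 3 carries the same fluoro as compound 1 on the sulfonamide aryl but keeps the ethyl of compound 2 on the core, so no measured pair isolates this change. For compound 3 the expected step from compound 2 is a 1.4-fold lower number from compound 2 to compound 3 (0.15 log units; within the scatter), a modest drift toward a lower number, not clearly beyond the scatter. Compound 3 is therefore estimated at 800 nM in this assay, within a range of 350 nM to 1800 nM.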

Compound 3, half-maximal inhibitory concentration: 4100 nM
Compound 3: the middle estimate sits 5.1-fold (0.71 log units) below what was measured; measured number outside the range, above it.
By their numbers in this assay, from the lowest: compound 1; then compound 2; then compound 3.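

In this assay, replacing 4-methylphenyl with 4-fluorophenyl on the sulfonamide gives a 3.7-fold higher number from compound 2 to compound 3 (0.56 log units; beyond the scatter), so with ethyl on the ring nitrogen, methyl is the group at this position that gives the lower number. With the fluoro held fixed, ethyl in place of phenyl on that amine nitrogen gives a 9.5-fold higher number from compound 1 to compound 3 (0.98 log units; beyond the scatter), which shows that the low number of compound 1 goes with its phenyl and not with its fluoro. Nothing shown here explains why either change moves the number in this direction.

From the compounds shown here alone, whether methyl would also give the lower number with phenyl on the ring nitrogen remains open, since the two changes have been read only on the ethyl side. Going by these compounds, it is equally open how a chloro, a methoxy or a trifluoromethyl would behave at this position on the sulfonamide aryl.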